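This account rests on a few compounds, and the source may have more. Where it says the series, first, only, none or still open, it means among the compounds named here.

Notes on the series. The shared core is carried by compound 1 `COc1cc(OCc2cccc(-c3ccc(C#N)cc3)c2)c2cc(-c3cn4nc(OC)sc4n3)oc2c1`, compound 2 `COc1cc(OCc2csc(-c3ccc(C(F)(F)F)cc3)n2)c2cc(-c3cn4nc(OC)sc4n3)oc2c1` and compound 3 `COc1cc(OCc2csc(-c3ccccc3)n2)c2cc(-c3cn4nc(OC)sc4n3)oc2c1`; compound 4 `COc1ccc(-c2cccc(COc3cc(OC)cc4oc(-c5cn6nc(OC)sc6n5)cc34)c2)nc1` is not yet measured. In an ADME assay on microsomes from liver (Homo sapiens) for metabolic stability (a higher number here means that the compound lasts longer, a lower number that the compound disappears faster), compound 1 reports > 2 h, which is a limit of the method and not a number. Compound 2 likewise reports a limit, > 2 h. Compound 3 gives 1.33 h. The measured range is bounded by the limit of > 2 h in this assay, at which 2 of the 3 values shown sit. Among the compounds with values here, the only single-point step measured is an at least 1.5-fold lower number from compound 2 to compound 3 (0.17 log units; that floor lies within the scatter), which bears on a different part of the molecule than the change now considered. The change from compound 1 to compound 4 is 5-methoxypyridin-2-yl in place of 4-cyanophenyl on an aromatic carbon. Within the data shown here, no measured step covers this change, and the one step available was small. A step of similar size, with no firm direction, is therefore expected in this assay, so the estimated step is a number no higher from compound 1 to compound 4 (the limit leaves the size open). Compound 4 is expected to give 2 h, with a range from 1 h to 4 h.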

Compound 4, half-life: 0.767 h
The estimate for compound 4 lay 2.6-fold (0.42 log units) above the measured number; the whole stated range lies above it.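

The change from 4-cyanophenyl to 5-methoxypyridin-2-yl gives an at least 2.6-fold lower number from compound 1 to compound 4 (0.41 log units; beyond the scatter). This position, on an aromatic carbon of a six-membered aromatic ring of carbon only, can therefore move the read-out in this assay beyond the scatter, which the earlier step, with its floor within the scatter, did not show. The size of the step remains only a floor because the value of compound 1 is a limit and not a number: the limit of > 2 h in this assay, at which 2 of the 4 values shown sit.

The change removes the nitrile and brings in a ring nitrogen and a methoxy group together, and the compounds shown do not separate these parts. As far as these compounds go, how an unsubstituted pyridin-2-yl, a 4-methoxyphenyl or an amine-bearing aryl group would read at this position in this assay also remains open.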